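The source may report more compounds than this note shows. Statements on the series, on what has been measured and on what is new or still open speak of the compounds shown alone.

Measured so far:
compound 1, `COC(=O)N1CCC(Oc2ncnc(Oc3ccc(/C=C4\SC(=O)NC4=O)cc3)c2C)CC1`: 1410 nM
compound 2, `Cc1c(Oc2ccc(/C=C3\SC(=O)NC3=O)cc2)ncnc1OC1CCN(C(=O)OCC(C)C)CC1`: 75.1 nM
compound 3, `COC(=O)N1CCC(Oc2cc(Oc3ccc(/C=C4\SC(=O)NC4=O)cc3)ncn2)CC1`: "not active" (no number reported)

All values are from a functional assay on CHO-K1 cells for agonist activity at Glucose-dependent insulinotropic receptor (Homo sapiens), read by cAMP accumulation and immunoassay, with a stated time of 1 h; on this read-out higher numbers stand for an effect only at larger amounts of compound and lower numbers for an effect already at smaller amounts. Compound 3 carries no number in this assay; it is recorded as inactive, and so it stands apart from compound 1 and compound 2, both of which gave measurable values.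

The next compound is compound 4, `CC(C)(C)OC(=O)N1CCC(Oc2cc(Oc3ccc(/C=C4\SC(=O)NC4=O)cc3)ncn2)CC1`. Its difference from compound 3 is tert-butyl in place of methyl on an oxygen next to a carbonyl group.

For the measured compounds named here, the only measured step touching this position is the one from compound 1 to compound 2, isopropyl in place of hydrogen on a saturated chain carbon bound to an oxygen next to a carbonyl group, which gave a 19-fold lower number from compound 1 to compound 2 (1.27 log units; beyond the scatter). Compound 1 and compound 2 share a core that differs from the shared core of compound 3 and compound 4, so that step is a rough guide only. On these data alone, a larger group on the same oxygen is therefore expected to lower the number for compound 4 relative to compound 3, but with compound 3 having no number, the starting point is unknown and the outcome is uncertain, with a real chance that compound 4 is again reported as inactive.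

Compound 4 is estimated at 3000 nM, with a range from 300 nM to 30000 nM.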

Compound 4, half-maximal effective concentration: 130 nM
Compound 4: the middle estimate sits 23-fold (1.36 log units) above what was measured, outside the stated range (below it).
By their numbers in this assay, from the lowest: compounds 2 and 4 (each within the scatter of the next); then compound 1.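

Compound 3 carries no number, so the step from it to compound 4, which gives 130 nM, cannot be read. No evidence bears on this result. The compounds shown leave open how large the effect of tert-butyl in place of methyl is on this core.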